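The compounds below may be only part of what the source reports. "The series", "measured", "known", "first", "only" and "open" are said of these compounds alone.

Measured so far in an ADME assay, in phosphate buffer, at 28 degrees C, at pH 7.0; on this read-out lower numbers stand for a shorter-lived compound and higher numbers for a longer-lived compound:
- compound 1, `COC(=O)[C@@H](O)[C@H]1C(=O)N2C(C(=O)O)=C(C(C)(C)C)O[C@H]12`, gives 6.2 h
- compound 2, `C[C@@H](F)[C@H]1C(=O)N2C(C(=O)O)=C(C(C)(C)C)O[C@H]12`, gives 3.5 h
- compound 3, `CC(C)(C)C1=C(C(=O)O)N2C(=O)[C@H](CNS(C)(=O)=O)[C@H]2O1`, gives 2.2 h

Compound 3 carries the lowest of the three numbers. Its nearest neighbour is compound 2, and the step of a 1.6-fold lower number from compound 2 to compound 3 (0.20 log units; within the scatter) falls within the scatter, so these two are not told apart. Compound 1 stands furthest away: the step of a 2.8-fold lower number from compound 1 to compound 3 (0.45 log units; beyond the scatter) is a modest one beyond the scatter. The remaining step, a 1.8-fold lower number from compound 1 to compound 2 (0.25 log units; within the scatter), also lies within the scatter.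

Compound 4, `CC(=O)NC[C@H]1C(=O)N2C(C(=O)O)=C(C(C)(C)C)O[C@H]12`, differs from compound 3 at one place: acetyl in place of methylsulfonyl on an amine nitrogen. None of the three measured steps touches this position; each of them swaps the whole substituent on the saturated ring carbon, whereas here the methanesulfonamido is trimmed to acetamido on the amine nitrogen. The measured steps therefore serve only as a guide to how much this series moves at all, which so far runs from inside the scatter up to a modest change.

For the measured compounds named here, with no direct precedent, the step of a 1.1-fold higher number from compound 3 to compound 4 (0.06 log units; within the scatter) is expected to stay within the scatter. The estimate for compound 4 in this assay is 2.5 h, with a range from 1.2 h to 5 h.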

Compound 4, half-life: < 3 h
Compound 4 gave a limit, no number; the forecaster's own chance of this, stated with the estimate: 0%; the middle value does not contradict the limit.
By their numbers in this assay, from the lowest: compounds 3, 2 and 1 (each within the scatter of the next, the first and the last beyond it).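

In this assay compound 4 gives < 3 h as a limit and not a number. For the compounds shown here, the exchange of methylsulfonyl for acetyl on the amine nitrogen therefore cannot be read against compound 3, and the only step that touches this position has no size. The result does add an at least 2.0-fold lower number from compound 1 to compound 4 (0.31 log units; beyond the scatter) for acetamidomethyl in place of hydroxy(methoxycarbonyl)methyl on the saturated ring carbon, a gap beyond the scatter that matches the direction of (methanesulfonamido)methyl in the same place, whereas an at least 1.1-fold lower number from compound 2 to compound 4 (0.06 log units; that floor lies within the scatter) is only a floor within the scatter and does not separate acetamidomethyl from 1-fluoroethyl.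

As far as these compounds go, how far compound 4 lies from its limit stays unknown, so acetyl and methylsulfonyl on this nitrogen remain unranked. The compounds shown also leave open how a free amine on the saturated chain carbon, or a longer acyl chain in place of acetyl, would read in this assay on the shared core.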